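Adding a Fluorine to a Weak Cytotoxic Quinolinone

This account rests on a few compounds, and the source may have more. Where it says the series, first, only, none or still open, it means among the compounds named here.

Compound 1 `Cc1ccc2[nH]c(=O)c(-c3nc4ccccc4[nH]3)cc2c1` was tested in a functional assay on SK-OV-3 cells (Homo sapiens) for cytotoxicity, read by MTT assay, with a stated time of 48 h; a higher number here means a weaker inhibitor, a lower number a stronger inhibitor. Compound 1 gives > 100000 nM, which is a limit of the assay rather than a number. Compound 2 `COc1ccc2[nH]c(=O)c(-c3nc4ccccc4[nH]3)cc2c1` likewise gives > 100000 nM, again a limit. The step that the two limits leave unreadable from compound 1 to compound 2 cannot be read because the limit of > 100000 nM in this assay, at which 2 of the 3 values shown sit, caps both values. Within the data shown here, compound 3 `O=c1[nH]c2ccccc2cc1-c1nc2cc(Br)ccc2[nH]1` differs from compound 1 in several places, so no single step connects the two. In this assay compound 3 gives 11400 nM.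

Compound 4 `Cc1ccc2[nH]c(=O)c(-c3nc4cc(F)ccc4[nH]3)cc2c1` is the next member: fluoro in place of hydrogen on an aromatic carbon. Among the measured compounds shown here, no measured step bears directly on this change, since the only readable value, that of compound 3, also involves loss of the methyl group. Compound 4 is therefore expected to stay close to where compound 1 stands, with the step of an at least 1.2-fold lower number from compound 1 to compound 4 (0.09 log units; that floor lies within the scatter) expected to be small and most likely still hidden by the assay limit. The estimate for compound 4 is 80000 nM, within 15000 nM to 300000 nM.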

Compound 4, half-maximal inhibitory concentration: > 100000 nM
Compound 4 was reported as a limit (the forecaster's own chance of this, stated with the estimate: 60%); at least 1.2-fold (0.09 log units) between middle value and limit.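

In this assay compound 4 gives > 100000 nM, which is a limit and not a number. Among these compounds, compound 1 is capped in the same way, so no step from compound 1 to compound 4 can be read: the limit of > 100000 nM in this assay, at which 3 of the 4 values shown sit. The compounds shown leave open whether fluoro in place of hydrogen changes cytotoxicity at all.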